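Compound 3: 2-fluorophenyl in place of 3-fluorophenyl

The source may hold more compounds than are shown below. What is called first, only, known or untested is meant among the compounds shown, and "the series" means these compounds.

Within the data shown here, compound 1 `C=CCn1c(=O)/c(=C\c2cccc(F)c2)[nH]c(=O)/c1=C\c1ccccc1OC` is the only member of this series with a number in a functional assay on HeLa cells (Homo sapiens) for cytotoxicity, read by CCK-8 assay, with a stated time of 72 h; on this read-out higher numbers stand for weaker inhibition and lower numbers for stronger inhibition; in that assay compound 1 gives 9100 nM. Compound 2 `C=CCn1c(=O)/c(=C\c2cccc(Br)c2)[nH]c(=O)/c1=C\c1cccc(Br)c1` is reported in this assay as "not active" (no number reported), with no figure attached, so it cannot serve as a comparison point. Among the measured compounds shown here, no step between two measured compounds exists in this set.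

Compound 3 `C=CCn1c(=O)/c(=C\c2ccccc2F)[nH]c(=O)/c1=C\c1ccccc1OC` differs from compound 1 by 2-fluorophenyl in place of 3-fluorophenyl on a double-bonded chain carbon bound to an aromatic carbon. The two contain the same atoms, joined differently. For the measured compounds named here, with one number in hand and no measured step of any kind, there is no precedent in this assay for the effect of such a rearrangement; the expectation is a step no larger than the usual scatter, with no preferred direction. Compound 3 is therefore expected to give roughly 9100 nM in this assay, somewhere between 3500 nM and 25000 nM, which corresponds to an expected step of no change at the digits printed from compound 1 to compound 3 (within the scatter).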

Compound 3, half-maximal inhibitory concentration: 45000 nM
The estimate for compound 3 lay 4.9-fold (0.69 log units) below the measured number, and the stated range ends below it.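

In this assay, among these compounds, 2-fluorophenyl in place of 3-fluorophenyl on a double-bonded chain carbon bound to an aromatic carbon gives a 4.9-fold higher number from compound 1 to compound 3 (0.69 log units; beyond the scatter), the first measured step. With the atoms unchanged and only their joining different, the number at this position is shown to depend on how the fluorophenyl group is arranged, and 3-fluorophenyl gives the stronger inhibition of the two. Nothing at hand accounts for this step.

Among the compounds shown here, one step on one pair cannot show whether the same change would act alike elsewhere on the shared core, and compound 2, having no number, allows no step to be read. Also open, going by these compounds, is how the number would respond to a chlorophenyl, or to a phenyl carrying an amine or a carboxylic acid, at this position.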